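The compounds below may be only part of what the source reports. "The series", "measured", "known", "first", "only" and "open" are said of these compounds alone.

Compound 1, `COc1cc(NC(=S)Nc2ccccc2)cc(OC)c1OC`, is a thiourea whose one nitrogen carries a trimethoxyphenyl group and whose other nitrogen carries a plain phenyl. In a functional assay on RAW264.7 cells (Mus musculus) for inhibition, read by Griess assay, with a stated time of 24 h (a lower number here means a stronger inhibitor, a higher number a weaker inhibitor), compound 1 gives 15200 nM. Within the data shown here, the only other measured compound, compound 2, `S=C(Nc1ccccc1)Nc1ccccn1`, keeps the phenyl on one nitrogen but carries a pyridyl in place of the trimethoxyphenyl on the other; in this assay compound 2 gives 182000 nM. Of the two numbers, compound 1 has the lower one, and its gap to compound 2 lies beyond the usual scatter of repeated measurements.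

The unmeasured compound 3, `COc1cc(NC(=S)NC#N)cc(OC)c1OC`, differs from compound 1 in one place: cyano in place of phenyl on an amide-type nitrogen. Among the measured compounds shown here, no measured pair shows this same change, so there is nothing to read its size from directly. Replacing a whole phenyl with a cyano on the thiourea nitrogen is a large alteration, and the expectation is a weakening of inhibition beyond the scatter rather than a gain. The step expected here is a 2.3-fold higher number from compound 1 to compound 3 (0.36 log units; beyond the scatter). Compound 3 is therefore estimated at 35000 nM in this assay, with a plausible range from 9000 nM to 140000 nM.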

Compound 3, half-maximal inhibitory concentration: 3900 nM
For compound 3 the middle estimate is 9.0-fold (0.95 log units) above the measured one; the measured number lies below the stated range.
By their numbers in this assay, from the lowest: compound 3; then compound 1; then compound 2.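

In this assay the swap of phenyl for cyano on the amide-type nitrogen gives a 3.9-fold lower number from compound 1 to compound 3 (0.59 log units; beyond the scatter) and so shows that a ring of carbon atoms is not needed at this place for inhibition to hold up; here the much smaller cyano, which brings a hydrogen-bond acceptor that the phenyl lacks, does better. Among these compounds, compound 1 and compound 2 share the phenyl on this nitrogen and differ only on the other side of the thiourea, so this is the first view of what this side of the molecule can tolerate. Nothing available explains why the number falls with this change.

A single replacement cannot separate a gain tied to the cyano itself from a gain that comes simply from removing the phenyl, and a methyl, a longer alkyl chain or an amide on the same nitrogen would help tell those two readings apart. As far as these compounds go, it also stays open whether cyano in place of phenyl would lower the number in the same way on the pyridyl side of compound 2.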